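A few compounds are considered here, and "the series" means these few. Any claim that something is new, unique, unknown or untested is made for them only; others in the source may bear on it.

Compound 1: `N#Cc1ccccc1CN1CCc2c(sc(NC(=O)c3ccccc3Cl)c2C(N)=O)C1` — 9500 nM
Compound 2: `NC(=O)c1c(NC(=O)c2ccccc2F)sc2c1CCN(Cc1cccc(Cl)c1)C2` — 23300 nM

Both compounds share the same core and were tested in a functional assay on MKN-74 cells (Homo sapiens) for antiproliferative activity, with a stated time of 24 h; a lower number here means a stronger inhibitor, a higher number a weaker inhibitor. Compound 1 has the lowest of the two numbers, and compound 2 sits beyond the usual scatter from it, so compound 1 is the stronger inhibitor of the pair on the numbers shown. Going by the values given here, no step between two measured compounds that differ in only one place is available, so nothing here says how a single change at the ring nitrogen shifts the read-out.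

Compound 3, `NC(=O)c1c(NC(=O)c2ccccc2Cl)sc2c1CCN(C(=S)Nc1ccccc1Br)C2`, differs from compound 1 in one place: a group of 10 heavy atoms (7 carbon, 1 nitrogen, 1 sulfur, 1 bromine; one six-membered aromatic ring of carbon only) in place of a group of 9 heavy atoms (8 carbon, 1 nitrogen; one six-membered aromatic ring of carbon only), on an amine nitrogen in a ring. Without a measured step to lean on, the expectation is that the step of a 1.1-fold higher number from compound 1 to compound 3 (0.02 log units; within the scatter) stays within the scatter, with wide uncertainty in either direction. Compound 3 is therefore estimated at 10000 nM, in a range from 3000 nM to 35000 nM.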

Compound 3, half-maximal inhibitory concentration: 10800 nM
Compound 3: middle estimate off by 1.1-fold (0.03 log units), on the low side; measured number inside the range.
By their numbers in this assay, from the lowest: compounds 1 and 3 (each within the scatter of the next); then compound 2.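

In this assay, replacing the 2-cyanobenzyl on the amine nitrogen in a ring with a group holding sulfur and bromine gives a 1.1-fold higher number from compound 1 to compound 3 (0.06 log units; within the scatter) and leaves the two compounds indistinguishable. Going by these compounds alone, this is the first comparison at this position that changes only one place, and it shows that the read-out can hold while a triple bond leaves and a hydrogen-bond donor and a double bond outside aromatic rings enter. Nothing measured here explains why these two different groups read alike.

Since the whole group changes in one step, the shown compounds cannot separate what the sulfur, the bromine or the hydrogen-bond donor each contributes. From the compounds shown here alone, it also remains open whether this tolerance extends to quite different groups on that nitrogen, such as a plain benzyl, a longer chain or a carboxylic acid.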